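Pyridin-2-yl in Place of Furan-2-yl at the Same Carbon

A few compounds are considered here, and "the series" means these few. Any claim that something is new, unique, unknown or untested is made for them only; others in the source may bear on it.

In an assay on HEK-293T cells for inhibition of diacylglycerol lipase-alpha (Homo sapiens), read by colorimetric assay (on this read-out lower numbers stand for stronger inhibition and higher numbers for weaker inhibition), compound 3 `O=C(CCCCCCc1ccccc1)c1nc(-c2ccco2)no1` gives 933 nM, the highest of the two numbers shown. Compound 1 `O=C(CCCCCc1ccccc1)c1nc2c(F)cccc2o1` gives 117 nM, a clearly lower number. Compound 2 `O=C(CCCCCCc1ccccc1)c1ncno1` reaches only the limit of this assay, > 10000 nM. Within the data shown here, the one measured step at the place in question is an at least 10-fold lower number from compound 2 to compound 3 (1.03 log units; beyond the scatter), and since it starts from the limit of > 10000 nM in this assay, at which 1 of the 3 values shown sits, its full size is not known. Compound 4 `O=C(CCCCCCc1ccccc1)c1nc(-c2ccccn2)no1` differs from compound 3 by pyridin-2-yl in place of furan-2-yl on an aromatic carbon. Among the measured compounds shown here, no measured step exchanges one aromatic group for another at this carbon, so compound 4 is expected to stay close to compound 3, with a 1.3-fold lower number from compound 3 to compound 4 (0.12 log units; within the scatter) inside the scatter. Compound 4 is therefore estimated at 700 nM, in a range from 200 nM to 2500 nM.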

Compound 4, half-maximal inhibitory concentration: 2750 nM
For compound 4 the middle estimate is 3.9-fold (0.59 log units) below the measured one; the measured number lies above the stated range.
By their numbers in this assay, from the lowest: compound 1; then compound 3; then compound 4. At a limit, above all of these: compound 2.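

At this carbon the choice of aromatic group matters in this assay, not only its presence: pyridin-2-yl in place of furan-2-yl gives a 2.9-fold higher number from compound 3 to compound 4 (0.47 log units; beyond the scatter). Pyridin-2-yl in place of hydrogen still gives an at least 3.6-fold lower number from compound 2 to compound 4 (0.56 log units; beyond the scatter), so both aromatic groups lower the number, furan-2-yl by more. Compound 2 stands at a limit, so the full size of that step is not known: the limit of > 10000 nM in this assay, at which 1 of the 4 values shown sits.

The compounds shown leave open how a phenyl or a pyridin-3-yl group on this carbon would read. They also do not tell what separates furan-2-yl from pyridin-2-yl here.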